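Removing One Methoxy from the Best Measured Compound

The source may hold more compounds than are shown below. What is called first, only, known or untested is meant among the compounds shown, and "the series" means these compounds.

Compound 1 `COc1cccc(/C=C/C(=O)/C=C/c2ccc(OCc3cn(CCOc4cc(=O)oc5ccccc45)nn3)c(OC)c2)c1`: 70%
Compound 2 `COc1cc(/C=C/C(=O)/C=C/c2cc(OC)c(OC)c(OC)c2)ccc1OCc1cn(CCOc2cc(=O)oc3ccccc23)nn1`: 89%

In a functional assay on HCT-116 cells (Homo sapiens) for inhibition, read by sulforhodamine B assay, with a stated time of 48 h, tested at 50 uM (on this read-out lower numbers stand for less inhibition of growth and higher numbers for more inhibition of growth at the one concentration tested), compound 2 stands highest of the two measured compounds at 89%, clearly ahead of compound 1. Compound 3 `COc1ccc(/C=C/C(=O)/C=C/c2ccc(OCc3cn(CCOc4cc(=O)oc5ccccc45)nn3)c(OC)c2)cc1OC` has not yet been measured. Its difference from compound 2 is hydrogen in place of methoxy on an aromatic carbon. In words, hydrogen sits in place of methoxy on an aromatic carbon, so 3,4,5-trimethoxyphenyl becomes 3,4-dimethoxyphenyl.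

Among the compounds with values here, only one measured step bears on this: a number 19 percentage points higher from compound 1 to compound 2 (beyond the scatter). It replaced 3-methoxyphenyl with 3,4,5-trimethoxyphenyl, a modest step beyond the scatter. The 3,4-dimethoxyphenyl group undoes only part of that replacement, so a smaller move downward is expected. A single step is thin evidence, and the drop may not clear the scatter.

The expected change is a number 9 percentage points lower from compound 2 to compound 3 (within the scatter).

For compound 3 the estimated value is 80%, with an expected range of 68% to 92%.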

Compound 3, percent growth inhibition at one concentration: 82%
Compound 3: middle estimate off by 2 percentage points, on the low side; low and high end bracket the measured number.
By their numbers in this assay, from the lowest: compound 1; then compounds 3 and 2 (each within the scatter of the next).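

In this assay, going from 3,4,5-trimethoxyphenyl to 3,4-dimethoxyphenyl gives a number 7 percentage points lower from compound 2 to compound 3 (within the scatter), so at this place on the ring, hydrogen in place of methoxy produces no change that can be told from scatter. Adding a methoxy to the ring of compound 1 gives a number 12 percentage points higher from compound 1 to compound 3 (beyond the scatter), which shows that the 3,4-dimethoxyphenyl group alone is enough to clear the scatter, while the further methoxy of compound 2 is not shown to add anything beyond it. No measurement here explains why these changes affect growth inhibition.

The compounds shown leave open whether a hydroxyl, a chlorine atom or an amine at this place would keep the inhibition seen with methoxy. A single tested concentration also leaves open how compound 2 and compound 3 would compare across a range of concentrations.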